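A second methoxy on compound 3

The compounds below may be only part of what the source reports. "The series", "measured", "known", "first", "only" and "open" are said of these compounds alone.

In an ADME assay on CCRF-CEM cells (Homo sapiens) for antiproliferative activity, with a stated time of 48 h (on this read-out lower numbers stand for stronger inhibition and higher numbers for weaker inhibition), compound 1 `C=C(Br)C(=O)Nc1ccc(C(=O)/C=C/c2ccccc2)cc1` gives 1500 nM, compound 2 `C=C(Br)C(=O)Nc1ccc(C(=O)/C=C/c2ccc(OC)cc2)cc1` gives 1100 nM and compound 3 `C=C(Br)C(=O)Nc1ccc(C(=O)/C=C/c2ccccc2OC)cc1` gives 580 nM. Compound 3 is clearly separated from only one of the others, as a 2.6-fold lower number from compound 1 to compound 3 (0.41 log units; beyond the scatter) shows, whereas a 1.9-fold lower number from compound 2 to compound 3 (0.28 log units; within the scatter) is not a clear difference.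

Compound 4 `C=C(Br)C(=O)Nc1ccc(C(=O)/C=C/c2ccc(OC)cc2OC)cc1` makes one change to compound 3: methoxy in place of hydrogen on an aromatic carbon. This places methoxy para to a large group and meta to a methoxy group. Among the measured compounds shown here, the closest precedent is a 1.4-fold lower number from compound 1 to compound 2 (0.13 log units; within the scatter), which adds methoxy para to the same large group. The larger 2.6-fold lower number from compound 1 to compound 3 (0.41 log units; beyond the scatter) puts methoxy elsewhere, so it bears less directly. No step beyond the scatter is therefore expected in this assay, and the expected change is a 1.3-fold lower number from compound 3 to compound 4 (0.11 log units; within the scatter). Compound 4 is estimated at 450 nM, with an expected range of 210 nM to 950 nM.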

Compound 4, half-maximal inhibitory concentration: 1100 nM
Compound 4: middle estimate off by 2.4-fold (0.39 log units), on the low side; measured number outside the range, above it.
By their numbers in this assay, from the lowest: compounds 3, 2, 4 and 1 (each within the scatter of the next, the first and the last beyond it).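

Adding methoxy para to the large group, on a ring that already carries a methoxy group, gives a 1.9-fold higher number from compound 3 to compound 4 (0.28 log units; within the scatter), and the same change made on the other compound with a single methoxy gives no change at the digits printed from compound 2 to compound 4 (within the scatter). Compound 4 therefore cannot be told apart from either compound with a single methoxy, so a second methoxy brings no clear gain over one. Nor does this change clearly behave differently on the two cores: the same change on two cores in this assay, a 1.4-fold lower number (0.13 log units; within the scatter) from compound 1 to compound 2 and a 1.9-fold higher number (0.28 log units; within the scatter) from compound 3 to compound 4, 2.6-fold (0.41 log units) apart, within the scatter of two such steps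

On these data alone, whether an amine or an ethoxy group at this place would move the number beyond the scatter remains open.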